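The compounds below may be only part of what the source reports. "The series", "measured", "known", "first", "only" and "open" are said of these compounds alone.

In a physicochemical assay for lipophilicity, using the shake flask method (a higher number here means a more lipophilic compound, a lower number a more polar compound), compound 1 (`C[C@H](Oc1cc2cc(C(N)=O)cc(F)c2nc1N)c1ncc(F)cc1-n1cccn1`) gives 2.1 and ranks second highest of the three measured compounds. Compound 2 (`C[C@H](Oc1cc2cc(C(N)=O)ccc2nc1N)c1cc(F)c(F)cc1-n1cccn1`) gives 3.2 and compound 3 (`C[C@H](Oc1cc2cc(F)ccc2nc1N)c1cc(C(=O)O)ccc1-n1cccn1`) gives 0.9, so compound 2 lies higher and compound 3 lower than compound 1, with both gaps lying beyond the scatter. Neither of these two differs from compound 1 in one place only, so their gaps cannot be tied to any single structural change.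

Compound 4 (`C[C@H](Oc1cc2cc(C(N)=O)ccc2nc1N)c1ncc(F)cc1-n1cccn1`) departs from compound 1 in one place, with hydrogen in place of fluoro on an aromatic carbon, and the rest of the structure is shared. Within the data shown here, no pair of measured compounds shows this swap on its own, so the data offer no direct measure of its size. A small downward move in this assay is expected, with a number 0.10 log units lower from compound 1 to compound 4 (within the scatter) as the estimated step, and that step would stay within the scatter. The expectation is anchored on compound 1 at 2.1 as the closest measured structure. Compound 4 is expected at 2 with the estimated range running from 1.6 to 2.4 on this reasoning.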

Compound 4, distribution coefficient: 1.9
Estimate against measurement, compound 4: 0.10 log units above, within the range that was stated.
By their numbers in this assay, from the lowest: compound 3; then compounds 4 and 1 (each within the scatter of the next); then compound 2.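

Among these compounds, compound 1 and compound 4 form the first pair here that differs in one place only, so the fluoro on the aromatic carbon, ortho to a fused ring and meta to a carbamoyl group, can now be looked at by itself. In this assay hydrogen in place of this fluoro gives a number 0.20 log units lower from compound 1 to compound 4 (within the scatter) and leaves the two compounds within the scatter of each other, so in this one pair the swap cannot be told apart from repeat measurement. Nothing at hand accounts for the size of this step.

The compounds shown leave open whether another group on this same aromatic carbon, such as a methoxy group, a nitrile or an amine, would also stay within the scatter of compound 4. Compound 2 and compound 3 each still differ from compound 4 in more than one place, and so their gaps remain untied to any single structural change.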